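The source may report more compounds than this note shows. Statements on the series, on what has been measured and on what is new or still open speak of the compounds shown alone.

Compound 3 `CCC/N=C1\S/C(=C\c2ccc(O)c(C(C)C)c2)C(=O)N1c1ccccc1C` is the point from which this step is taken. In a physicochemical assay for solubility, measured as kinetic solubility (a higher number here means a more soluble compound, a lower number a less soluble compound), compound 3 gives 79000 nM, and it stands level with compound 1 `CCC/N=C1\S/C(=C\c2ccc(O)cc2)C(=O)N1c1ccccc1C`, which in this assay gives 79000 nM. The step of no change at the digits printed from compound 1 to compound 3 (within the scatter) thus shows that an isopropyl in place of hydrogen on an aromatic carbon left the solubility where it was. Compound 2 `Cc1ccccc1N1C(=O)/C(=C/c2ccc(O)c(Cl)c2)S/C1=N\CCO` in this assay gives > 250000 nM, which is a limit of the assay and not a number. That limit is described by the limit of > 250000 nM in this assay, at which 1 of the 3 values shown sits.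

Compound 4 `CCC/N=C1\S/C(=C\c2ccc(O)c(Cl)c2)C(=O)N1c1ccccc1C` has not yet been measured. It differs from compound 3 by chloro in place of isopropyl on an aromatic carbon. Going by the values given here, the one measured step that bears on this change is no change at the digits printed from compound 1 to compound 3 (within the scatter), and it was within the scatter. Given that a change at this same aromatic carbon in the step of no change at the digits printed from compound 1 to compound 3 (within the scatter) moved nothing, the chloro is expected to leave the solubility of compound 4 close to that of compound 3, with an expected step of no change at the digits printed from compound 3 to compound 4 (within the scatter). Compound 4 is therefore estimated at 79000 nM in this assay, with a range from 30000 nM to 200000 nM.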

Compound 4, solubility: 79000 nM
For compound 4 middle estimate and measured number coincide at the digits printed; measured number inside the range.
By their numbers in this assay, from the lowest: compounds 1, 3 and 4 (each within the scatter of the next). At a limit, above all of these: compound 2.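

In this assay, the aromatic carbon ortho to a hydroxy group has now carried hydrogen, isopropyl and chloro on an otherwise unchanged core, and the new readings are no change at the digits printed from compound 3 to compound 4 (within the scatter) and no change at the digits printed from compound 1 to compound 4 (within the scatter). Chloro therefore could not be told apart from either isopropyl or hydrogen at this position, which the single earlier step could not show for a second group. Compound 4 also gives the first step that can be read beyond the scatter, and it lies away from this position, with methyl in place of hydroxy on a saturated chain carbon, two bonds along the chain from a double-bonded nitrogen, as an at least 3.1-fold lower number from compound 2 to compound 4 (0.50 log units; beyond the scatter), a step that starts from a limit of the assay and not a number: the limit of > 250000 nM in this assay, at which 1 of the 4 values shown sits.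

The compounds shown leave open whether an amine or a carboxylic acid at this aromatic carbon would read the same as chloro, isopropyl and hydrogen. They also leave open how large the step on the chain really is, and how a longer chain on the double-bonded nitrogen would read with chloro kept on the ring.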